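Aryl-to-cyclohexyl swap at the benzylic-type carbon

This account rests on a few compounds, and the source may have more. Where it says the series, first, only, none or still open, it means among the compounds named here.

Among the compounds with values here, compound 2 `O=C(O)c1ccc(NC(c2cccnc2)c2ccc3cccnc3c2O)cc1` is one of two compounds measured in an assay on isolated protein for inhibition of CAAX prenyl protease 2 (Homo sapiens), with stated times of 60 s and 60 min (a lower number here means a stronger inhibitor, a higher number a weaker inhibitor), where compound 2 gives 14000 nM. Its neighbour is compound 1 `O=C(O)c1ccc(NC(c2ccc(F)cc2)c2ccc3cccnc3c2O)cc1`, which in this assay gives 8200 nM. Within the data shown here, compound 2 holds the highest of the two numbers, but the only step, a 1.7-fold higher number from compound 1 to compound 2 (0.23 log units; within the scatter), lies within the scatter, so the two compounds cannot be ordered on these data.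

Compound 3 `O=C(O)c1ccc(NC(c2ccc3cccnc3c2O)C2CCCCC2)cc1` is not yet measured. It differs from compound 2 as follows: cyclohexyl in place of pyridin-3-yl on a saturated chain carbon bound to an aromatic carbon and a nitrogen on an aromatic ring.

Among the measured compounds shown here, the one measured step exchanges one six-membered aromatic ring for another on this same saturated chain carbon and moves the number by a 1.7-fold higher number from compound 1 to compound 2 (0.23 log units; within the scatter). For the measured compounds named here, no measured step replaces an aromatic ring with a non-aromatic ring, so the step to compound 3 is not covered; the nearest analogy shows only a change within the scatter.

Compound 3 is therefore expected to stay close to compound 2, with an estimated step of a 1.4-fold lower number from compound 2 to compound 3 (0.15 log units; within the scatter) in this assay. The estimate for compound 3 in this assay is 10000 nM, within a range of 3000 nM to 35000 nM.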

Compound 3, half-maximal inhibitory concentration: 9800 nM
Estimate against measurement, compound 3: 1.0-fold (0.01 log units) above; measured number inside the range.
By their numbers in this assay, from the lowest: compounds 1, 3 and 2 (each within the scatter of the next).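

In this assay, putting cyclohexyl on the saturated chain carbon gives a 1.4-fold lower number from compound 2 to compound 3 (0.15 log units; within the scatter) and a 1.2-fold higher number from compound 1 to compound 3 (0.08 log units; within the scatter), so this non-aromatic ring of carbon only cannot be told apart from either aromatic ring. Within the data shown here, the earlier step exchanged only one six-membered aromatic ring for another, whereas these steps show that, on these three compounds, neither an aromatic ring at this position nor the ring nitrogen of pyridin-3-yl is needed for a number in this range. No independent data are available to explain why the number holds across these rings.

All three compounds carry a six-membered ring at this carbon, so the compounds shown leave open how the number responds to a group of a different kind or size, such as a methyl group, a longer alkyl chain, or a cyclohexyl ring bearing an amine or a carboxylic acid. They also leave open whether any change at this position can move the number beyond the scatter, since no step shown here does so.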